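Triazole nitrogen substituent and antiproliferative potency in the series

A few compounds are considered here, and "the series" means these few. Any claim that something is new, unique, unknown or untested is made for them only; others in the source may bear on it.

Measured compounds:
compound 1, `CN(CCNCc1cn(-c2ccc(Cl)cc2)nn1)CCNc1ccnc2cc(Cl)ccc12`, 9500 nM
compound 2, `CN(CCNCc1cn(Cc2nc3cc(Cl)ccc3[nH]2)nn1)CCNc1ccnc2cc(Cl)ccc12`, 65000 nM
compound 3, `CN(CCNCc1cn(-c2ccnc3cc(Cl)ccc23)nn1)CCNc1ccnc2cc(Cl)ccc12`, 18000 nM

All three share one core and differ only in the group on the aromatic nitrogen of the triazole. In a functional assay on HCC827 cells (Homo sapiens) for antiproliferative activity, read by sulforhodamine B assay, with a stated time of 72 h (a higher number here means a weaker inhibitor, a lower number a stronger inhibitor), compound 1 gives the lowest of the three numbers; compound 3 sits nearest to it, with a 1.9-fold higher number from compound 1 to compound 3 (0.28 log units; within the scatter), while compound 2 is the furthest, with a 6.8-fold higher number from compound 1 to compound 2 (0.84 log units; beyond the scatter). Between the two heteroaryl variants the step is a 3.6-fold lower number from compound 2 to compound 3 (0.56 log units; beyond the scatter).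

Compound 4, `CN(CCNCc1cn(CCC(=O)Nc2ccccn2)nn1)CCNc1ccnc2cc(Cl)ccc12`, has not yet been measured in this assay. Its change from compound 1 is 2-((pyridin-2-yl)carbamoyl)ethyl in place of 4-chlorophenyl on an aromatic nitrogen.

Going by the values given here, two measured steps bear on this. The direct swap of one aromatic ring for another, compound 1 to compound 3, stayed within the scatter. Placing a spacer between the triazole nitrogen and the aromatic ring, as in compound 2, gave a 6.8-fold higher number from compound 1 to compound 2 (0.84 log units; beyond the scatter). Compound 4 also carries a chain between the triazole nitrogen and its ring, so a step of the second kind, weakening beyond the scatter, is expected rather than none.

For compound 4 the expected value in this assay is 35000 nM, within 12000 nM to 100000 nM, which is expected to mean a 3.7-fold higher number from compound 1 to compound 4 (0.57 log units; beyond the scatter).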

Compound 4, half-maximal inhibitory concentration: > 200000 nM
Compound 4 gave a limit, no number (the forecaster's own chance of this, stated with the estimate: 20%); middle value at least 5.7-fold (0.75 log units) away from the limit.
By their numbers in this assay, from the lowest: compounds 1 and 3 (each within the scatter of the next); then compound 2. At a limit, above all of these: compound 4.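

In this assay compound 4 stands at a limit of the assay, not at a number: the limit of > 200000 nM in this assay, at which 1 of the 4 values shown sits. Going by these compounds alone, the triazole nitrogen therefore does not accept every group equally: 2-((pyridin-2-yl)carbamoyl)ethyl gives an at least 21-fold higher number from compound 1 to compound 4 (1.32 log units; beyond the scatter) and an at least 11-fold higher number from compound 3 to compound 4 (1.04 log units; beyond the scatter), both large, whereas the changes among the earlier compounds were modest or within the scatter. Compound 2 also has a saturated chain carbon on this nitrogen, yet the step is still an at least 3.0-fold higher number from compound 2 to compound 4 (0.48 log units; beyond the scatter), so that carbon alone does not set the level of the series and the group it carries also counts.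

The entering group differs from the 4-chlorophenyl of compound 1 at once in its chain, its carbonyl and amide hydrogen, its pyridine-type ring and its lack of chlorine, and the compounds shown do not separate these features. A 4-chlorophenyl amide on the same ethyl chain, or a simple benzyl group on the triazole nitrogen, would begin to show which of them accounts for the loss.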